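Working notes: triazole arm in place of the methylpiperazine chain

The source may report more compounds than this note shows. Statements on the series, on what has been measured and on what is new or still open speak of the compounds shown alone.

Three compounds of the shared core have numbers in a functional assay on MCF7 cells (Homo sapiens) for cytotoxicity, read by MTT assay, with a stated time of 72 h; a lower number here means a stronger inhibitor, a higher number a weaker inhibitor. Compound 2 `CN1CCN(CCCCn2c3c(c4ccccc42)C(=O)c2c[n+]([O-])c4ccccc4c2C3=O)CC1` gives 100 nM, the lowest of the three. Compound 1 `CC1(C)OCC(Cn2cc(Cn3c4c(c5ccccc53)C(=O)c3c[n+]([O-])c5ccccc5c3C4=O)nn2)O1` gives 290 nM, and compound 3 `CN1CCN(CCCCCCn2c3c(c4ccccc42)C(=O)c2c[n+]([O-])c4ccccc4c2C3=O)CC1` gives 400 nM. Within the data shown here, the only step between measured compounds that differ in a single place is a 4.0-fold higher number from compound 2 to compound 3 (0.60 log units; beyond the scatter), so merely lengthening the chain that carries the methylpiperazine already costs potency beyond the scatter.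

Compound 4 `O=C1c2c[n+]([O-])c3ccccc3c2C(=O)c2c1c1ccccc1n2Cc1cn(C[C@@H](O)CO)nn1` awaits measurement. Relative to compound 2 the change is 1-(2,3-dihydroxypropyl)-1H-1,2,3-triazol-4-yl in place of 3-(4-methylpiperazin-1-yl)propyl on a saturated chain carbon bound to an aromatic nitrogen. Among the measured compounds shown here, no measured step covers this exchange directly: the step from compound 2 to compound 3 concerns only chain length on the same side chain, and compound 1 carries a closely related triazole-bearing arm but no step between compound 1 and compound 4 has been worked out. The relevant pointer is therefore that compound 1 gives 290 nM, sitting between compound 2 and compound 3.

Compound 4 is expected to land close to compound 1 because compound 1 gives 290 nM with a side chain of the same kind. The estimate for compound 4 is 300 nM, with a range of 100 nM to 900 nM. The expected step is a 3.0-fold higher number from compound 2 to compound 4 (0.48 log units; beyond the scatter), a weakening beyond the scatter rather than a gain.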

Compound 4, half-maximal inhibitory concentration: 600 nM
Compound 4: middle estimate off by 2.0-fold (0.30 log units), on the low side; low and high end bracket the measured number.
By their numbers in this assay, from the lowest: compound 2; then compounds 1, 3 and 4 (each within the scatter of the next, the first and the last beyond it).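

Putting 1-(2,3-dihydroxypropyl)-1H-1,2,3-triazol-4-yl in place of 3-(4-methylpiperazin-1-yl)propyl on a saturated chain carbon bound to an aromatic nitrogen gives a 6.0-fold higher number from compound 2 to compound 4 (0.78 log units; beyond the scatter) in this assay and so loses potency beyond the scatter, while a 1.5-fold higher number from compound 3 to compound 4 (0.18 log units; within the scatter) stays within the scatter, leaving compound 4 level with the longer methylpiperazine chain of compound 3. The end of the triazole arm also matters in its own right: 1,2-dihydroxyethyl in place of 2,2-dimethyl-1,3-dioxolan-4-yl gives a 2.1-fold higher number from compound 1 to compound 4 (0.32 log units; beyond the scatter) and is a modest weakening beyond the scatter, so the free diol does not recover potency relative to the protected form. No measurement on hand accounts for any of these steps.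

Still open, from the compounds shown here alone, is whether a triazole arm ending in a dimethylamino group or a carboxylic acid, rather than the diol or its dioxolane, would bring the number in this assay closer to that of compound 2. Also open, going by these compounds, are the effect of the opposite configuration at the defined stereocentre of compound 4 and of a propyl chain carrying the methylpiperazine.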